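The compounds below may be only part of what the source reports. "The series", "measured", "known", "first", "only" and "open" are said of these compounds alone.

Compound 1 `O=C1/C(=C/c2cccnc2)CN(S(=O)(=O)c2ccccc2)C/C1=C\c1ccccc1F` gives 4800 nM 
Compound 2 `O=C1/C(=C/c2ccncc2)CN(S(=O)(=O)c2ccccc2)C/C1=C\c1ccccc1F` gives 8400 nM 

For the measured compounds named here, in a functional assay on QGY-7703 cells (Homo sapiens) for cytotoxicity, read by MTT assay, with a stated time of 24 h (on this read-out higher numbers stand for weaker inhibition and lower numbers for stronger inhibition), compound 2 gives 8400 nM and lies within the scatter of compound 1, its only neighbour so far. Compound 3 `O=C1/C(=C/c2ccncc2)CN(S(=O)(=O)c2ccc(Cl)cc2)C/C1=C\c1ccccc1F` matches compound 2 apart from one change: chloro in place of hydrogen on an aromatic carbon turns phenyl into 4-chlorophenyl, with chloro in place of hydrogen on an aromatic carbon. Going by the values given here, the only measured step, a 1.8-fold higher number from compound 1 to compound 2 (0.24 log units; within the scatter), exchanges pyridin-3-yl for pyridin-4-yl and stays within the scatter. Among the compounds with values here, no measured step involves chloro, so none bears directly on this change, and the data give no firm direction. No shift beyond the scatter is therefore expected in this assay for this change. The expected size of the change is a 1.4-fold lower number from compound 2 to compound 3 (0.15 log units; within the scatter) and this is only an estimate. For compound 3 the estimated value is 6000 nM with an expected range from 2500 nM to 13000 nM at its two ends.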

Compound 3, half-maximal inhibitory concentration: 12500 nM
For compound 3 the middle estimate is 2.1-fold (0.32 log units) below the measured one; measured number inside the range.
By their numbers in this assay, from the lowest: compounds 1, 2 and 3 (each within the scatter of the next, the first and the last beyond it).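

For the compounds shown here, this is the first change on the phenyl of the phenylsulfonyl group, as the earlier step concerned only the pyridine. In this assay the swap of phenyl for 4-chlorophenyl gives a 1.5-fold higher number from compound 2 to compound 3 (0.17 log units; within the scatter) and so does not separate the two compounds. A chloro on this aromatic carbon, para to a large group, therefore leaves the cytotoxicity reading indistinguishable from that with hydrogen, at least with the pyridin-4-yl group in place. Nothing measured here offers an explanation for this result.

A single substituent at one position cannot show whether this position is insensitive to change in general. An amine, a carboxylic acid or a methoxy group on the same carbon could still move the number beyond the scatter, and the same chloro might act differently alongside pyridin-3-yl.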